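Removing the benzyl ether in a cytotoxicity series

The source may report more compounds than this note shows. Statements on the series, on what has been measured and on what is new or still open speak of the compounds shown alone.

Compound 1 `CCOC(=O)CCCCCOc1cccc(CN(C(=O)c2ccc(-c3cccc(C(C)=O)c3)cc2)C(C)C)c1`: in an ADME assay on BJ cells (Homo sapiens) for cytotoxicity, read by CellTiter-Glo and resazurin assay, with a stated time of 72 h (on this read-out higher numbers stand for an effect only at larger amounts of compound and lower numbers for an effect already at smaller amounts), compound 1 gives only a limit, > 26000 nM.
Compound 2 `CCOC(=O)CCCCCOc1cccc(CN(C(=O)c2ccc(-c3cccc(OCC(C)C)c3)cc2)C(C)C)c1`: in this assay compound 2 gives only a limit, > 26000 nM.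
Compound 3 `CCOC(=O)CCCCCOc1cccc(CN(C(=O)c2ccc(-c3cccc(OCc4ccccc4)c3)cc2)C(C)C)c1`: in this assay compound 3 gives only a limit, > 26000 nM.

Compound 3 therefore stands at the limit of this assay, and so do the two other compounds, which is what the limit of > 26000 nM in this assay, at which 3 of the 3 values shown sit, records. Compound 4 `CCOC(=O)CCCCCOc1cccc(CN(C(=O)c2ccc(-c3cccc(O)c3)cc2)C(C)C)c1` differs from compound 3 by hydrogen in place of benzyl on an oxygen on an aromatic ring. The measured steps that come closest are the exchanges on the same aromatic ring: a step that the two limits leave unreadable from compound 1 to compound 2, a step that the two limits leave unreadable from compound 1 to compound 3 and a step that the two limits leave unreadable from compound 2 to compound 3. None of them can be read, because the limit of > 26000 nM in this assay, at which 3 of the 3 values shown sit, places every value at the limit; they show only that acetyl, isobutoxy and benzyloxy on that ring all leave the read-out there. Within the data shown here, no measured step thus points in a direction for the loss of the benzyl group. On the strength of the limit of > 26000 nM in this assay, at which 3 of the 3 values shown sit, the step from compound 3 to compound 4 is expected to be a number no higher from compound 3 to compound 4 (the limit leaves the size open), that is, no change beyond the scatter. For compound 4 the expected value in this assay is 26000 nM, within 10000 nM to 60000 nM, and most likely again reported only as a limit.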

Compound 4, half-maximal effective concentration: > 26000 nM
Compound 4 ended at the assay's limit; the forecaster's own chance of this, stated with the estimate: 80%; the middle value sits exactly at the limit.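

Compound 4, like compound 1, compound 2 and compound 3, gives only a limit in this assay, so no step among these compounds can be read: the limit of > 26000 nM in this assay, at which 4 of the 4 values shown sit.

The compounds shown leave open whether acetyl, isobutoxy, benzyloxy and hydroxy on that ring differ at all in this assay, and at what amount of compound any of the four has an effect.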